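Swapping Allyl for Butyl on a Shared Core

The compounds below may be only part of what the source reports. "The series", "measured", "known", "first", "only" and "open" are said of these compounds alone.

Small changes to a molecule can show whether a part of it matters for a biological effect. Here, the test is an ADME assay on SW480 cells (Homo sapiens) for cytotoxicity, read by MTT assay, with a stated time of 72 h; on this read-out lower numbers stand for stronger inhibition of growth and higher numbers for weaker inhibition of growth. In this test, compound 1 (`CCCCCCCCCCNC(=O)C1C(C(=O)O)[C@@H]2CC[C@H]1O2`), which carries a decyl chain on its amide, gives 10000 nM. Compound 2 (`C=CCNC(=O)C1C(C(=O)O)[C@@H]2CC[C@H]1O2`), which has the same core with an allyl chain, gives 10000 nM. Compound 2 therefore stands level with compound 1, and the two values show no difference.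

Compound 3 (`CCCCNC(=O)C1C(C(=O)O)[C@@H]2CC[C@H]1O2`) has not yet been measured. It differs from compound 2 by one change: propyl in place of vinyl on a saturated chain carbon bound to an amide-type nitrogen. In words, propyl takes the place of vinyl on a saturated chain carbon bound to an amide-type nitrogen, which turns the allyl chain into a butyl chain.

Two measurements are thin evidence, but the decyl and allyl chains give the same reading, so nothing here points to a large shift. In this assay, the step of no change at the digits printed from compound 2 to compound 3 (within the scatter) is expected to stay within the usual scatter. For compound 3, the estimated value is 10000 nM, with an expected range of 5000 nM to 20000 nM.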

Compound 3, concentration for 50% growth inhibition: 10000 nM
The estimate for compound 3 equals the measured number at the digits printed; the measured number falls inside the stated range.
By their numbers in this assay, from the lowest: compounds 1, 2 and 3 (each within the scatter of the next).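

The step from allyl to butyl removes the chain's double bond, and in this assay it gives no change at the digits printed from compound 2 to compound 3 (within the scatter). On a saturated chain carbon bound to an amide-type nitrogen, then, swapping vinyl for propyl leaves no visible mark on this read-out, a point that the comparison of the decyl and allyl compounds could not settle on its own. Replacing hexyl with hydrogen on a saturated chain carbon, four bonds along the chain from an amide-type nitrogen, turns the decyl chain into the butyl chain and gives no change at the digits printed from compound 1 to compound 3 (within the scatter), so among these three compounds neither the double bond nor the change from decyl to butyl separates the readings; no supporting measurement is available to explain this flat result.

The compounds shown leave open whether a chain that ends in an amine or a phenyl ring would read differently in this assay. They also leave open whether a methyl ester in place of the carboxylic acid on the shared core would move the value away from this shared reading.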